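Adding a methoxy group to a second phenyl ring

The compounds below may be only part of what the source reports. "The series", "measured", "known", "first", "only" and "open" are said of these compounds alone.

Measured compounds:
- compound 1, `O=C1N=C(N2N=C(c3ccccc3)CC2c2ccccc2O)S/C1=C1/C(=O)Nc2ccccc21`: 2130 nM
- compound 2, `COc1ccc(C2CC(c3ccccc3)=NN2C2=NC(=O)/C(=C3\C(=O)Nc4ccccc43)S2)cc1`: 1620 nM
- compound 3, `COc1ccc(C2CC(c3ccccc3)=NN2C2=NC(=O)/C(=C3\C(=O)Nc4ccc(Br)cc43)S2)cc1`: 180 nM

These three compounds were tested in a functional assay on cells (Cancer cell lines, Homo sapiens) for cytotoxicity, read by sulforhodamine B assay, with a stated time of 48 h; on this read-out lower numbers stand for stronger inhibition of growth and higher numbers for weaker inhibition of growth. Compound 2 stands second highest of the three numbers: its nearest neighbour is compound 1, whose value sits within the scatter of compound 2, while compound 3 lies furthest away, with a clearly lower number.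

Compound 4, `COc1ccc(C2=NN(C3=NC(=O)/C(=C4\C(=O)Nc5ccccc54)S3)C(c3ccc(OC)cc3)C2)cc1`, has not been measured yet. It differs from compound 2 in one place: methoxy in place of hydrogen on an aromatic carbon. The shared core is unchanged.

Two measured steps can be weighed. The step of a 1.3-fold lower number from compound 1 to compound 2 (0.12 log units; within the scatter) also altered a substituent on a phenyl ring that hangs from the pyrazoline part of the core, and it changed the number only within the scatter. The step of a 9.0-fold lower number from compound 2 to compound 3 (0.95 log units; beyond the scatter) was larger, but it placed a bromo on the fused ring system of the core, a different part of the molecule from the one altered here. Within the data shown here, no measured step adds a methoxy to the phenyl ring that compound 4 changes.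

Given the small effect of the one comparable step, the change from compound 2 to compound 4 is expected to be a 1.1-fold lower number from compound 2 to compound 4 (0.03 log units; within the scatter), no shift beyond the scatter. The value estimated for compound 4 is 1500 nM, with a range from 600 nM to 4000 nM.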

Compound 4, concentration for 50% growth inhibition: 43900 nM
For compound 4 the middle estimate is 29-fold (1.47 log units) below the measured one; the whole stated range lies below it.
By their numbers in this assay, from the lowest: compound 3; then compounds 2 and 1 (each within the scatter of the next); then compound 4.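

In this assay, the change from phenyl to 4-methoxyphenyl gives a 27-fold higher number from compound 2 to compound 4 (1.43 log units; beyond the scatter), so this place on the molecule, on a six-membered aromatic ring of carbon only and para to a large group, is far from indifferent to a small added group. The earlier steps did not reveal this: a 1.3-fold lower number from compound 1 to compound 2 (0.12 log units; within the scatter) stayed within the scatter and a 9.0-fold lower number from compound 2 to compound 3 (0.95 log units; beyond the scatter) went towards stronger inhibition of growth, whereas this is the only step shown that clearly weakens it. No measurement here explains the loss, so the result records what happened at this position but not the reason for it.

The compounds shown leave open whether the loss belongs to methoxy alone or would also follow from another group at the same place, such as fluoro, hydroxy, an amine or a carboxylic acid. They also leave open whether the bromo group of compound 3, placed in the same molecule as this methoxy, would win back any of the lost growth inhibition.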